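The source may report more compounds than this note shows. Statements on the series, on what has been measured and on what is new or still open speak of the compounds shown alone.

Measured so far in a functional assay on MGC-803 cells (Homo sapiens) for antiproliferative activity, read by CCK-8 assay, with a stated time of 72 h; on this read-out higher numbers stand for weaker inhibition and lower numbers for stronger inhibition:
- compound 1 `O=C(Nc1ccc(-c2cnc3cc(N4CCN(C5CC5)CC4)ccn23)cc1)c1ccc([N+](=O)[O-])o1`: 1650 nM
- compound 2 `O=C(Nc1ccc(-c2cnc3cc(Br)ccn23)cc1)c1ccc([N+](=O)[O-])o1`: 750 nM
- compound 3 `O=C(Nc1ccc(-c2cnc3cc(Cl)ccn23)cc1)c1ccc([N+](=O)[O-])o1`: 4620 nM

Compound 1 stands second highest of the three numbers. The step of a 2.2-fold lower number from compound 1 to compound 2 (0.34 log units; beyond the scatter) lowers the number, the step of a 2.8-fold higher number from compound 1 to compound 3 (0.45 log units; beyond the scatter) raises it, and the two halogens differ from each other by a 6.2-fold higher number from compound 2 to compound 3 (0.79 log units; beyond the scatter).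

Compound 4 `O=C(Nc1ccc(-c2cnc3ccccn23)cc1)c1ccc([N+](=O)[O-])o1` is not yet measured. It differs from compound 1 by hydrogen in place of 4-cyclopropylpiperazin-1-yl on an aromatic carbon. Within the data shown here, no measured step removes the substituent at this carbon altogether; the steps that bear on it are the two replacements from compound 1, one down and one up, and the halogen swap between compound 2 and compound 3, which together show that changes at this carbon shift the number by a modest amount in either direction. The centre of the estimate for compound 4 is set a little above compound 1, because a 2.8-fold higher number from compound 1 to compound 3 (0.45 log units; beyond the scatter) is the step to the smaller of the two groups tried there, but the range has to cover both directions. Compound 4 is expected to give 2500 nM in this assay, with a range from 700 nM to 9000 nM. The estimated step of a 1.5-fold higher number from compound 1 to compound 4 (0.18 log units; within the scatter) is therefore expected to be modest and upward.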

Compound 4, half-maximal inhibitory concentration: 590 nM
Estimate against measurement, compound 4: 4.2-fold (0.63 log units) above, outside the stated range (below it).
By their numbers in this assay, from the lowest: compounds 4 and 2 (each within the scatter of the next); then compound 1; then compound 3.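

In this assay the carbon opposite the ring nitrogen now has an unsubstituted reference, and 4-cyclopropylpiperazin-1-yl proves unnecessary for activity on this read-out (a 2.8-fold lower number from compound 1 to compound 4 (0.45 log units; beyond the scatter)). Against that reference, bromo cannot be told apart from hydrogen (a 1.3-fold lower number from compound 2 to compound 4 (0.10 log units; within the scatter)), whereas chloro stands clearly apart (a 7.8-fold lower number from compound 3 to compound 4 (0.89 log units; beyond the scatter)), so the two halogens do not behave alike and the number does not follow substituent size across these four compounds. No available measurement accounts for these differences.

From the compounds shown here alone, it remains open whether chloro is an isolated case or whether other small groups at this carbon, such as fluoro, methoxy or methyl, also raise the number relative to hydrogen. A simple amine such as morpholin-4-yl or an unsubstituted piperazine would show whether the cyclopropyl part of the departing group matters.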